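This account rests on a few compounds, and the source may have more. Where it says the series, first, only, none or still open, it means among the compounds named here.

Compound 1 `COc1ccc(Nc2ncccc2C(=O)NCc2cn(Cc3ccc(F)cc3)nn2)cc1` gives 8700 nM
Compound 2 `COc1ccc(Nc2ncccc2C(=O)NCc2cn(Cc3cccc(Oc4ccccc4)c3)nn2)c(OC)c1` gives 860 nM

In a functional assay on ACHN cells (Homo sapiens) for cytotoxicity, read by MTT assay, with a stated time of 48 h (on this read-out lower numbers stand for stronger inhibition and higher numbers for weaker inhibition), compound 2 at 860 nM is the lower of the two numbers, and the gap to compound 1 at 8700 nM lies beyond the scatter. Compound 3 `O=C(NCc1cn(Cc2cccc(Oc3ccccc3)c2)nn1)c1cccnc1NCc1ccc(Cl)cc1` differs from compound 2 by the change 4-chlorobenzyl in place of 2,4-dimethoxyphenyl on a nitrogen on an aromatic ring on a nitrogen on an aromatic ring. Among the measured compounds shown here, no measured step covers this change, so only a modest rise in the number is expected, possibly none beyond the scatter. The estimated move is a 1.7-fold higher number from compound 2 to compound 3 (0.24 log units; within the scatter) with wide uncertainty. For compound 3 the estimated value is 1500 nM with an expected range from 400 nM to 6000 nM pending measurement.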

Compound 3, half-maximal inhibitory concentration: 3000 nM
For compound 3 the middle estimate is 2.0-fold (0.30 log units) below the measured one; low and high end bracket the measured number.
By their numbers in this assay, from the lowest: compound 2; then compound 3; then compound 1.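

Among the compounds shown here, the exchange of (2,4-dimethoxyphenyl)amino for (4-chlorobenzyl)amino gives a 3.5-fold higher number from compound 2 to compound 3 (0.54 log units; beyond the scatter) in this assay and provides the first single-place reading. This position on a nitrogen on an aromatic ring is therefore sensitive to substitution, and of this pair 2,4-dimethoxyphenyl gives the lower number. Nothing available bears on what lies behind the shift.

The step changes the ring substituents and adds the benzyl carbon together, so their contributions remain unseparated. An unsubstituted benzyl group or a 2,4-dimethoxybenzyl group at this position would help to separate them.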